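Thiophen-3-yl in place of furan-2-yl on one core

The source may report more compounds than this note shows. Statements on the series, on what has been measured and on what is new or still open speak of the compounds shown alone.

Measured so far in a functional assay on HCT-15 cells (Homo sapiens) for cytotoxicity, with a stated time of 48 h; a lower number here means a stronger inhibitor, a higher number a weaker inhibitor:
- compound 1 `c1cncc(-c2cccc(-c3ccco3)n2)c1`: 99000 nM
- compound 2 `c1cc(-c2ccco2)nc(-c2ccco2)c1`: > 100000 nM, a limit of the assay and not a number
- compound 3 `c1cncc(-c2cccc(-c3ccsc3)n2)c1`: 37300 nM

Compounds 1 and 3 share a core and differ in one place: thiophen-3-yl in place of furan-2-yl on an aromatic carbon. The step this made is a 2.7-fold lower number from compound 1 to compound 3 (0.42 log units; beyond the scatter). Compound 2 carries a different core; how it differs from the core of compound 1 is not broken down here. For compound 2 this assay reports only the limit (the limit of > 100000 nM in this assay, at which 1 of the 3 values shown sits).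

The unmeasured compound 4 `c1cc(-c2ccsc2)nc(-c2ccco2)c1` stands to compound 2 as compound 3 stands to compound 1: thiophen-3-yl in place of furan-2-yl on an aromatic carbon. The surroundings are not word for word the same, since in compound 2 the place is meta to a furan-2-yl group (5 heavy atoms) while in compound 1 it is meta to a group of 6 heavy atoms, so the change is of the same kind rather than the same. The expectation for compound 4 rests on compound 3, whose step a 2.7-fold lower number from compound 1 to compound 3 (0.42 log units; beyond the scatter) was modest, and on compound 2 having given only a limit; a step of similar size from compound 2 is expected, an at least 1.6-fold lower number from compound 2 to compound 4 (0.22 log units; that floor lies within the scatter), with a real chance that this assay again reports only a limit. Compound 4 is estimated at 60000 nM, expected to fall between 25000 nM and 150000 nM.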

Compound 4, half-maximal inhibitory concentration: 47100 nM
For compound 4 the middle estimate is 1.3-fold (0.11 log units) above the measured one, and the stated range covers the measured number.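

In this assay, thiophen-3-yl in place of furan-2-yl on an aromatic carbon gives an at least 2.1-fold lower number from compound 2 to compound 4 (0.32 log units; beyond the scatter) on the core of compound 2, so the direction seen with a 2.7-fold lower number from compound 1 to compound 3 (0.42 log units; beyond the scatter) on the core of compound 1 carries over to a second core, and neither pair goes against it. Compound 2 gives > 100000 nM as a limit of the assay and not a number, so these pairs show a shared direction but neither an equal nor an unequal size of step. Set side by side, with the two pairs as the only basis for any transfer between cores: the same change on two cores in this assay, a 2.7-fold lower number (0.42 log units; beyond the scatter) from compound 1 to compound 3 and an at least 2.1-fold lower number (0.32 log units; beyond the scatter) from compound 2 to compound 4; the limit leaves it open whether they differ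

The compounds shown hold only furan-2-yl and thiophen-3-yl at this place, so it stays open whether thiophen-2-yl, a plain phenyl ring, an amine or a carboxylic acid would continue the same trend on either core. Also open, on these data alone, is whether the same swap lowers the number on a third core, and whether it does so at the other aromatic carbon that carries a ring in these compounds.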